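This account rests on a few compounds, and the source may have more. Where it says the series, first, only, none or still open, it means among the compounds named here.

Compound 1 `CC(C(=O)NCc1ccc(C(F)(F)F)nc1-c1cccc(Cl)c1)c1ccc(NS(C)(=O)=O)c(F)c1` stands lowest of the three numbers in an assay on CHO cells for antagonist activity at transient receptor potential cation channel subfamily V member 1 (Homo sapiens), read by FLIPR (a lower number here means a stronger inhibitor, a higher number a weaker inhibitor), giving 0.5 nM. Compound 2 `CC(C(=O)NCc1ccc(C(F)(F)F)nc1-c1ccc(Cl)c(Cl)c1)c1ccc(NS(C)(=O)=O)c(F)c1` gives 0.9 nM, a step of a 1.8-fold higher number from compound 1 to compound 2 (0.26 log units; within the scatter). Compound 3 `COc1ccc(-c2nc(C(F)(F)F)ccc2CNC(=O)C(C)c2ccc(NS(C)(=O)=O)c(F)c2)cc1OC` gives 25.6 nM, a step of a 51-fold higher number from compound 1 to compound 3 (1.71 log units; beyond the scatter). Compound 4 `Cc1ccc(CCc2nc(C(F)(F)F)ccc2CNC(=O)C(C)c2ccc(NS(C)(=O)=O)c(F)c2)cc1` differs from compound 1 at the same aromatic carbon: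

2-(4-methylphenyl)ethyl in place of 3-chlorophenyl on an aromatic carbon

Both measured steps bear on this position: replacing one ring substituent left the number within the scatter, whereas exchanging the whole 3-chlorophenyl group cost a great deal. A 2-(4-methylphenyl)ethyl group is a larger departure from 3-chlorophenyl than either, so a step beyond the scatter toward a higher number is expected, of uncertain size. Compound 4 is therefore estimated at 10 nM, in a range from 1.5 nM to 70 nM, an expected step of a 20-fold higher number from compound 1 to compound 4 (1.30 log units; beyond the scatter).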

Compound 4, inhibition constant: 0.6 nM
For compound 4 the middle estimate is 17-fold (1.22 log units) above the measured one; measured number outside the range, below it.
By their numbers in this assay, from the lowest: compounds 1, 4 and 2 (each within the scatter of the next); then compound 3.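

In this assay, the aromatic ring of this substituent need not sit directly on the core: the 2-(4-methylphenyl)ethyl group shows a 1.2-fold higher number from compound 1 to compound 4 (0.08 log units; within the scatter) and a 1.5-fold lower number from compound 2 to compound 4 (0.18 log units; within the scatter) within the scatter of both chlorinated phenyl groups. The large cost of 3,4-dimethoxyphenyl is therefore no general penalty for leaving 3-chlorophenyl, with a 43-fold lower number from compound 3 to compound 4 (1.63 log units; beyond the scatter) at the same position. Going by these compounds, whether a shorter benzyl group, a longer chain or an amine within the chain would keep the number this low remains open. No evidence given here explains why compound 3 stands apart.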